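A few compounds are considered here, and "the series" means these few. Any claim that something is new, unique, unknown or untested is made for them only; others in the source may bear on it.

Measured compounds in an assay on HEK293 cells for agonist activity at Bile acid receptor (Homo sapiens), read by a luciferase reporter; on this read-out lower numbers stand for smaller maximal responses and higher numbers for larger maximal responses:
- compound 1 `CC(C)OC(=O)C1CN(C(=O)C2CCCCC2)CC(C)(C)c2cc(C#N)[nH]c21`: 127%
- compound 2 `CC(C)OC(=O)C1=CN(C(=O)c2ccc(F)cc2)CC(C)(C)c2cc(C#N)[nH]c21`: 119%
- compound 3 `CC(C)OC(=O)C1=CN(C(=O)c2cccc(Cl)c2)CC(C)(C)c2cc(C#N)[nH]c21`: 122%

Compound 1 shows the highest of the three numbers, but its distance to compound 3 and to compound 2 lies within the scatter, so no ordering among the three is supported. Within the data shown here, the only single-point step among the measured compounds is a number 3 percentage points higher from compound 2 to compound 3 (within the scatter), which also falls within the scatter; it concerns the aryl group on the carbonyl carbon, not the change considered here.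

Compound 4 `CC(C)OC(=O)C1CN(C(=O)c2ccc(F)cc2)CC(C)(C)c2cc(C#N)[nH]c21` is not yet measured. It differs from compound 1 as follows: 4-fluorophenyl in place of cyclohexyl on a carbonyl carbon. Among the measured compounds shown here, no measured pair shows this exact exchange. Compound 2 carries the same 4-fluorophenyl on the carbonyl carbon, though on a different core, and gives a number close to that of compound 1. On that basis the expected step of a number 7 percentage points lower from compound 1 to compound 4 (within the scatter) is none beyond the scatter. For compound 4 the estimate in this assay is 120%, with a range from 100% to 140%.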

Compound 4, largest response reached (reported as efficacy), in percent of the reference or control that the assay uses: 85%
Estimate against measurement, compound 4: 35 percentage points above; measured number below the stated range.
By their numbers in this assay, from the lowest: compound 4; then compounds 2, 3 and 1 (each within the scatter of the next).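

In this assay the exchange of cyclohexyl for 4-fluorophenyl on the carbonyl carbon gives a number 42 percentage points lower from compound 1 to compound 4 (beyond the scatter) and shows that the maximal response on the core of compound 1 depends on the group at this position. The earlier compounds shown here, whose numbers all lie within the scatter of one another, did not show this: with the same 4-fluorophenyl group, compound 2 gives 119% and compound 4 gives 85% on its own core, so the result for this group on one core does not carry over to the other. No measurement at hand bears on the reason for this difference.

As far as these compounds go, whether the loss follows from the aromatic ring or from the fluorine stays open, and unsubstituted phenyl at this position would separate the two. Also open, from the compounds shown here alone, is how cyclopentyl or tert-butyl would behave on the core of compound 1.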